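One carbon less on the chain in a maximal electroshock series

The source may hold more compounds than are shown below. What is called first, only, known or untested is meant among the compounds shown, and "the series" means these compounds.

Of the compounds shown here, three have been tested in a functional assay on the whole organism (strain Swiss) with Mus musculus as the target, in the maximal electroshock model, with a stated time of 0.5 h, at a dose of 100 mg/kg by the intraperitoneal route; on this read-out higher numbers stand for a stronger effect at the one dose given and lower numbers for a weaker effect. Compound 1, `CC(C(=O)N1CCN(c2ccccc2F)CC1)N1C(=O)CCC1=O`, gives 0%, and compound 2, `CCC(C(=O)N1CCN(c2ccccc2F)CC1)N1C(=O)CCC1=O`, gives 0%. These two share a core and differ by hydrogen in place of methyl on a saturated chain carbon, two bonds along the chain from an amide-type nitrogen in a ring and a carbonyl carbon; the step between them is no change at the digits printed from compound 2 to compound 1 (within the scatter). Compound 3, `CCC(C(=O)N1CCN(c2cccc(C(F)(F)F)c2)CC1)N1C(=O)CCC1=O`, gives 50% in this assay, the highest of the three values and beyond the scatter above both compound 1 and compound 2. How the core of compound 3 differs from that of compound 2 is not broken down here.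

Compound 4, `CC(C(=O)N1CCN(c2cccc(C(F)(F)F)c2)CC1)N1C(=O)CCC1=O`, has not yet been measured. It differs from compound 3 by hydrogen in place of methyl on a saturated chain carbon, two bonds along the chain from an amide-type nitrogen in a ring and a carbonyl carbon, the same change at the same place as that between compound 2 and compound 1. Going by these compounds, on the core of compound 1 and compound 2 that change produced no step beyond the scatter, but both of those values sit at the bottom of the scale, so it remains open whether the change carries over to a core that shows activity. Compound 4 is therefore expected to give about 40%, with a range from 10% to 70%. This corresponds to an expected step of a number 10 percentage points lower from compound 3 to compound 4 (within the scatter).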

Compound 4, a percentage reported as activity, at one dose (the size of the read-out at that dose, not a potency): 75%
Compound 4: middle estimate off by 35 percentage points, on the low side, and the stated range ends below it.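

In this assay, the change from ethyl to methyl on the chain gives a number 25 percentage points higher from compound 3 to compound 4 (beyond the scatter). Set beside the earlier step, the same change does not carry over from one core to the other with the same size: the same change on two cores in this assay, no change at the digits printed (within the scatter) from compound 2 to compound 1 and a number 25 percentage points higher (beyond the scatter) from compound 3 to compound 4, 25 percentage points apart, beyond the scatter of two such steps

This does not establish a rule for the series, since only two cores are shown, and with compound 1 at 0% and compound 2 at 0% that pair sits at the bottom of the scale, where a gain from this change could stay out of sight at the one dose given.

The compounds shown leave open how a longer chain such as propyl, or a phenyl group on the same chain carbon, would read on the core of compound 4. They also leave open whether a chlorine in place of the trifluoromethyl group would keep the activity seen with compound 3 and compound 4.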